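The source may report more compounds than this note shows. Statements on the series, on what has been measured and on what is new or still open speak of the compounds shown alone.

Measured so far in an ADME assay on MDCK cells (Canis lupus familiaris) for cytotoxicity, read by microscopy, with a stated time of 3 days; a higher number here means that more compound is tolerated, a lower number that less compound is tolerated:
- compound 1 `CCCCCCCCCCCCCCC(=O)Oc1ccc(COP(=O)(OCc2ccc(OC(=O)CCCC)cc2)OP(=O)(O)OP(=O)(O)OC[C@H]2O[C@@H](n3ccnc(C(N)=O)c3=O)[C@H](O)[C@@H]2O)cc1`: 16000 nM
- compound 2 `NC(=O)c1nccnc1O`: > 250000 nM, which is a limit of the assay and not a number
- compound 3 `NC(=O)c1nccn([C@@H]2O[C@H](CO)[C@@H](O)[C@H]2O)c1=O`: > 250000 nM, again a limit of the assay

Where compound 2 stands: its value in this assay is only a limit, so no minimum cytotoxic concentration is known for it, and the same holds for compound 3. Only compound 1 returns a number. The limit is the common case here, because of the limit of > 250000 nM in this assay, at which 2 of the 3 values shown sit.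

The step followed is from compound 2 to compound 4 `NC(=O)c1nc(F)cnc1O`. The change is fluoro in place of hydrogen on an aromatic carbon. Within the data shown here, no pair of measured compounds differing in one place is available, so no measured step size exists to lean on, and nothing among the measured values ties this change to any direction in this assay.

With compound 2 sitting at the limit, compound 4 is expected to behave alike, and the step of a number no higher from compound 2 to compound 4 (the limit leaves the size open) is expected to be none beyond the scatter. For compound 4 the estimate in this assay is 250000 nM, with a range from 100000 nM to 250000 nM, and most likely the assay will again report only a limit.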

Compound 4, minimum cytotoxic concentration: > 250000 nM
Compound 4 ended at the assay's limit; the forecaster's own chance of this, stated with the estimate: 80%; the middle value sits exactly at the limit.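

No step can be read from compound 2 to compound 4 in this assay, since both results are limits of the assay and not numbers: the limit of > 250000 nM in this assay, at which 3 of the 4 values shown sit.

The compounds shown leave open whether fluoro in place of hydrogen on an aromatic carbon alters the minimum cytotoxic concentration at all.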